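This account rests on a few compounds, and the source may have more. Where it says the series, first, only, none or still open, it means among the compounds named here.

Measured compounds:
- compound 1, `CCCOC(=O)C1=C(C)NC(=O)NC1c1cccs1`: 32%
- compound 2, `CC1=C(C(=O)OCC(C)C)C(c2cccs2)NC(=O)N1`: 11%

In an assay on membranes from HeLa cells for displacement of a labelled ligand from adenosine receptor A3 (Homo sapiens), read by scintillation counting, with a stated time of 180 min, tested at 1 uM (a higher number here means more inhibition at the concentration tested (going by the name of the read-out), a lower number less inhibition), compound 1 gives 32%, while compound 2 gives 11%. Compound 2 stands lowest of the two numbers; its nearest neighbour is compound 1, and the step of a number 21 percentage points lower from compound 1 to compound 2 (beyond the scatter) lies beyond the scatter. That step came with a methyl in place of hydrogen on a saturated chain carbon bound to two saturated chain carbons, a change within the ester chain.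

Compound 3, `CC1=C(C(=O)OC(C)(C)C)C(c2cccs2)NC(=O)N1`, is the next compound. tert-butyl in place of isobutyl on an oxygen next to a carbonyl group

Among the measured compounds shown here, the only step that bears on it is a number 21 percentage points lower from compound 1 to compound 2 (beyond the scatter), which also altered the ester chain and lowered the read-out modestly. Because compound 2 already sits at 11%, a further change of this kind is expected to give at most a small step, a number 3 percentage points lower from compound 2 to compound 3 (within the scatter), within the scatter. Compound 3 is therefore estimated at 8%, in the range -6% to 24%.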

Compound 3, a percentage reported as inhibition, at one concentration (the size of the read-out at that concentration, not a potency): 7%
For compound 3 the middle estimate is 1 percentage points above the measured one; the measured number falls inside the stated range.
By their numbers in this assay, from the lowest: compounds 3 and 2 (each within the scatter of the next); then compound 1.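

Exchanging isobutyl for tert-butyl on an oxygen next to a carbonyl group gives a number 4 percentage points lower from compound 2 to compound 3 (within the scatter), so in this assay these two branched chains cannot be told apart. Set against the propyl chain, tert-butyl gives a number 25 percentage points lower from compound 1 to compound 3 (beyond the scatter), which means that both branched chains shown now read lower than propyl, and none of the three compounds goes against this. Nothing measured alongside these numbers accounts for the result.

The compounds shown leave open whether a shorter chain such as methyl or ethyl, a longer chain such as pentyl, or a benzyl group at this oxygen would bring the read-out above that of compound 1. Among the compounds shown here, they also leave open how an amide in place of the ester would read, and, with a single concentration, they give no potency for any compound.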